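Aryl substitution on the ring nitrogen: compound 3 to compound 4

The source may hold more compounds than are shown below. What is called first, only, known or untested is meant among the compounds shown, and "the series" means these compounds.

For the measured compounds named here, compound 3 `COc1cc2c(Oc3ccc(NC(=O)c4nn(-c5ccc(F)cc5)c(=O)c5ccccc45)cc3F)ccnc2cc1OCCCN1CCN(C)CC1` gives 150 nM in a functional assay on MKN-45 cells (Homo sapiens) for cytotoxicity, read by MTT assay, with a stated time of 72 h (on this read-out lower numbers stand for stronger inhibition and higher numbers for weaker inhibition), the lowest of the three numbers so far. Compound 2 `COc1cc2c(Oc3ccc(NC(=O)c4nn(-c5cccc(F)c5)c(=O)c5ccccc45)cc3F)ccnc2cc1OCCCN1CCCC1` gives 160 nM, within the scatter of compound 3, so no order between the two can be stated. Compound 1 `COc1cc2c(Oc3ccc(NC(=O)c4nn(-c5ccccc5)c(=O)c5ccccc45)cc3F)ccnc2cc1OCCCN1CCCC1` gives 530 nM, the furthest away, beyond the scatter from compound 3.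

Compound 4 `COc1cc2c(Oc3ccc(NC(=O)c4nn(-c5ccccc5Br)c(=O)c5ccccc45)cc3F)ccnc2cc1OCCCN1CCN(C)CC1` carries the change (2-bromophenyl in place of 4-fluorophenyl on an aromatic nitrogen), that is, 2-bromophenyl in place of 4-fluorophenyl on an aromatic nitrogen, next to the ring nitrogen, ortho to a group of 1 heavy atom.

Going by the values given here, the only single-point step measured on this aryl ring is a 3.3-fold lower number from compound 1 to compound 2 (0.52 log units; beyond the scatter), a fluoro in place of hydrogen. Compounds 2 and 3 differ in two places at once, so their values only show that the two arrangements land within the scatter of each other. Among the compounds with values here, no measured step covers bromine, nor a change at the position that the 2-bromophenyl occupies, so the direction is not anchored by the series.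

For compound 4 a step of about a 2.0-fold higher number from compound 3 to compound 4 (0.30 log units; within the scatter) is expected, a modest rise that may well stay within the scatter. Compound 4 is estimated at 300 nM, with a range from 100 nM to 1000 nM.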

Compound 4, half-maximal inhibitory concentration: 400 nM
The estimate for compound 4 lay 1.3-fold (0.12 log units) below the measured number, within the range that was stated.
By their numbers in this assay, from the lowest: compounds 3 and 2 (each within the scatter of the next); then compounds 4 and 1 (each within the scatter of the next).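

In this assay, for the compounds shown here, a 2.7-fold higher number from compound 3 to compound 4 (0.43 log units; beyond the scatter) is the first single-place change on the aryl group on the aromatic nitrogen in which the number rises, and the rise lies beyond the scatter. Read beside a 3.3-fold lower number from compound 1 to compound 2 (0.52 log units; beyond the scatter), it shows that both measured single-place changes on this aryl group move the number beyond the scatter, but in opposite directions, so this site responds to what it carries and halogen substitution here does not have one fixed outcome across the listed compounds. Going by these compounds alone, nothing measured so far accounts for the size or direction of the new step.

Since 2-bromophenyl replaces 4-fluorophenyl as a whole, the halogen and its place on the ring change together, and the compounds shown do not separate the contribution of bromine from that of its place. Going by these compounds, it also remains open how this site responds to non-halogen groups on the aryl ring, such as a methoxy group, an amine or a carboxylic acid.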